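Pyrazinyl to methoxyphenyl exchange on the pyrazole acid series

This account rests on a few compounds, and the source may have more. Where it says the series, first, only, none or still open, it means among the compounds named here.

Compound 3 `Cc1nn(-c2nc(-c3ccc(Cl)c(Cl)c3)c(SC(C)C)s2)c(C(=O)O)c1-c1cnccn1` gives the highest number among the three measured compounds in a functional assay on BJAB cells (Homo sapiens) for antiproliferative activity, with a stated time of 4 days; a higher number here means that more compound is needed for the effect, a lower number that less compound is needed: compound 3 gives 14000 nM. Compound 1 `COc1ccc(-c2c(C)nn(-c3nc(-c4ccc(Cl)c(Cl)c4)c(SC(C)C)s3)c2C(=O)O)cc1` gives 2100 nM and compound 2 `Cc1nn(-c2nc(-c3ccc(Cl)c(Cl)c3)c(SC(C)C)s2)c(C(=O)O)c1-c1cccc(Cl)c1C` gives 5100 nM. The steps leading onto compound 3 were a 6.7-fold higher number from compound 1 to compound 3 (0.82 log units; beyond the scatter) and a 2.7-fold higher number from compound 2 to compound 3 (0.44 log units; beyond the scatter), both beyond the scatter. Compound 4 `COc1cccc(-c2c(C)nn(-c3nc(-c4ccc(Cl)c(Cl)c4)c(SC(C)C)s3)c2C(=O)O)c1` carries 3-methoxyphenyl in place of pyrazin-2-yl on an aromatic carbon. Read in reverse, both earlier steps point to a lower number for compound 4, with a size lying between the two exchanges already seen; no measured compound goes against this. Compound 4 is therefore expected at 3200 nM, with a range of 1100 nM to 9000 nM. The expected step is a 4.4-fold lower number from compound 3 to compound 4 (0.64 log units; beyond the scatter).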

Compound 4, half-maximal effective concentration: 14000 nM
The estimate for compound 4 lay 4.4-fold (0.64 log units) below the measured number, outside the stated range (above it).
By their numbers in this assay, from the lowest: compound 1; then compound 2; then compounds 3 and 4 (each within the scatter of the next).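

In this assay the carbon-only ring does not by itself lower the number, as 3-methoxyphenyl matches pyrazin-2-yl at this position: no change at the digits printed from compound 3 to compound 4 (within the scatter). The methoxy placement on the phenyl matters in this pair, with a 6.7-fold higher number from compound 1 to compound 4 (0.82 log units; beyond the scatter), and 3-chloro-2-methylphenyl also gives the lower number, with a 2.7-fold higher number from compound 2 to compound 4 (0.44 log units; beyond the scatter). No measurement on hand accounts for these differences. On these data alone, it remains open whether 4-aminophenyl would track 4-methoxyphenyl or 3-methoxyphenyl at this position.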